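This account rests on a few compounds, and the source may have more. Where it says the series, first, only, none or still open, it means among the compounds named here.

Measured compounds in an assay on CHO-K1 cells for displacement of a labelled ligand from adenosine receptor A1 (Homo sapiens), read by scintillation counting, with a stated time of 60 min; on this read-out lower numbers stand for stronger inhibition and higher numbers for weaker inhibition:
compound 1 `CCCCC/C=C/C=C/C=N/Nc1nc(N)c2ncn([C@@H]3O[C@H](CO)[C@@H](O)[C@H]3O)c2n1` gives 2 nM
compound 2 `Nc1nc(N/N=C/c2cncs2)nc2c1ncn2[C@@H]1O[C@H](CO)[C@@H](O)[C@H]1O` gives 22 nM
compound 3 `Nc1nc(N/N=C/c2cccnc2Cl)nc2c1ncn2[C@@H]1O[C@H](CO)[C@@H](O)[C@H]1O` gives 4.6 nM

Compound 3 stands second highest of the three numbers. Its nearest neighbour is compound 1, with a 2.3-fold higher number from compound 1 to compound 3 (0.36 log units; beyond the scatter); the furthest is compound 2, with a 4.8-fold lower number from compound 2 to compound 3 (0.68 log units; beyond the scatter).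

Compound 4 `Nc1nc(N/N=C/c2ccc(Br)cn2)nc2c1ncn2[C@@H]1O[C@H](CO)[C@@H](O)[C@H]1O` is not yet measured in this assay. It differs from compound 3 by 5-bromopyridin-2-yl in place of 2-chloropyridin-3-yl on a carbon with a double bond to nitrogen.

The step that bears most on this change is the exchange of one aromatic ring for another at the same carbon, a 4.8-fold lower number from compound 2 to compound 3 (0.68 log units; beyond the scatter), which was modest. Among the measured compounds shown here, the only large step in the set, an 11-fold higher number from compound 1 to compound 2 (1.04 log units; beyond the scatter), involved loss of the chain and a different ring, so it is less informative here. For the measured compounds named here, no measured step swaps one six-membered aromatic ring for another, so the direction is uncertain; a step of at most modest size is expected, if any beyond the scatter.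

For compound 4 the expected value in this assay is 7 nM, within 2.5 nM to 20 nM, meaning an estimated step of a 1.5-fold higher number from compound 3 to compound 4 (0.18 log units; within the scatter).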

Compound 4, inhibition constant: 4.7 nM
The estimate for compound 4 lay 1.5-fold (0.17 log units) above the measured number, and the stated range covers the measured number.
By their numbers in this assay, from the lowest: compound 1; then compounds 3 and 4 (each within the scatter of the next); then compound 2.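

In this assay, 5-bromopyridin-2-yl in place of 2-chloropyridin-3-yl on the carbon with a double bond to nitrogen gives no change beyond the scatter (a 1.0-fold higher number from compound 3 to compound 4 (0.01 log units; within the scatter)), so this position accepts either of these two halogen-bearing six-membered aromatic rings alike. The other two steps place compound 4 where compound 3 already stood, with the 1,3-thiazol-5-yl compound on one side (a 4.7-fold lower number from compound 2 to compound 4 (0.67 log units; beyond the scatter)) and the chain of compound 1 on the other (a 2.4-fold higher number from compound 1 to compound 4 (0.37 log units; beyond the scatter)). No measurement here offers an explanation for the two pyridinyl groups reading alike.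

The step changes the halogen and its ring together, so the contribution of each stays unresolved. Also open, as far as these compounds go, is whether an amine or a carboxylic acid on the pyridine ring in place of the halogen would keep these numbers.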